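Pyridinylsulfonyl in place of pyridinylmethyl on a piperazine nitrogen

This account rests on a few compounds, and the source may have more. Where it says the series, first, only, none or still open, it means among the compounds named here.

The study compares two measured compounds in a functional assay (Oryctolagus cuniculus) for antagonist activity at platelet-activating factor receptor (Cavia porcellus); a lower number here means a stronger inhibitor, a higher number a weaker inhibitor. Compound 1 `COc1cc(CCC(=O)N2CCN(C(=O)c3cc(OC)c(OC)c(OC)c3)CC2)cc(OC)c1OC` gives 73000 nM in this assay, a weak result. Compound 2 `O=C(CC(c1ccccc1)c1ccccc1)N1CCN(Cc2cccnc2)CC1` is much stronger: in this assay compound 2 gives 520 nM, the lowest of the two numbers and well beyond the scatter from compound 1. Compound 3 `O=C(CC(c1ccccc1)c1ccccc1)N1CCN(S(=O)(=O)c2ccncc2)CC1` is not yet measured. It differs from compound 2 in one place: (pyridin-4-yl)sulfonyl in place of (pyridin-3-yl)methyl on an amine nitrogen in a ring. Among the measured compounds shown here, no measured pair in this set shows what such an exchange does, so the direction is open; a change of this kind is expected to shift the number only modestly, and the step expected a 1.7-fold higher number from compound 2 to compound 3 (0.24 log units; within the scatter) is estimated to lie near the edge of the scatter, toward a weaker result. For compound 3 in this assay the expected value is 900 nM, with a range from 200 nM to 4000 nM.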

Compound 3, half-maximal inhibitory concentration: 11000 nM
The estimate for compound 3 lay 12-fold (1.09 log units) below the measured number, and the stated range ends below it.
By their numbers in this assay, from the lowest: compound 2; then compound 3; then compound 1.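

In this assay, the exchange of (pyridin-3-yl)methyl for (pyridin-4-yl)sulfonyl on the amine nitrogen in the ring gives a 21-fold higher number from compound 2 to compound 3 (1.33 log units; beyond the scatter), so this position responds strongly to the change, toward a weaker inhibitor. Among the compounds shown here, the step is the first single-place comparison in the set, and the rest of the structure is shared, so the loss belongs to this one exchange, in which both the link to the ring and the point of attachment on the pyridine differ. Nothing available accounts for the size of this loss.

The compounds shown leave open whether the sulfonyl link or the shift from pyridin-3-yl to pyridin-4-yl carries the loss. A (pyridin-4-yl)methyl or (pyridin-3-yl)sulfonyl group on this nitrogen would separate the two.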